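The source may report more compounds than this note shows. Statements on the series, on what has been measured and on what is new or still open speak of the compounds shown alone.

Going by the values given here, in a functional assay on MCF7 cells (Homo sapiens) for cytotoxicity, read by MTT assay, with a stated time of 24 h (a lower number here means a stronger inhibitor, a higher number a weaker inhibitor), compound 1 `O=C1/C(=C/c2ccccc2F)CN(Cc2cn(Cc3ccc(F)cc3)nn2)C/C1=C\c1ccccc1F` gives 6000 nM, and among the three values shown it is the only one that is a number rather than a limit. Compound 2 `COc1ccc(/C=C2\CN(C(=S)SCc3cn(Cc4ccccc4Cl)nn3)C/C(=C\c3ccc(OC)cc3)C2=O)cc1` reaches only the limit of the assay, > 100000 nM. Compound 3 `O=C1/C(=C/c2ccccc2F)CN(C(=S)SCc2cn(Cc3cccc(Cl)c3)nn2)C/C1=C\c1ccccc1F` likewise reaches only the limit, > 100000 nM. Two of the three values thus sit at the limit of > 100000 nM in this assay, at which 2 of the 3 values shown sit, and compound 1 stands alone beneath it. Among the compounds with values here, compounds 2 and 3 differ from compound 1 in more than one place, so no single step connects them to it; their values show only that they are weaker than compound 1 in this assay.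

Compound 4 `O=C1/C(=C/c2ccccc2F)CN(Cc2cn(Cc3ccccc3Cl)nn2)C/C1=C\c1ccccc1F` has not yet been measured. It differs from compound 1 in one place: 2-chlorophenyl in place of 4-fluorophenyl on a saturated chain carbon bound to an aromatic nitrogen. Within the data shown here, no measured pair isolates this change, so its effect can only be anticipated. The core of compound 1 is untouched, and the group that changes sits on a saturated chain carbon bound to an aromatic nitrogen, away from the core. The step of a 1.5-fold higher number from compound 1 to compound 4 (0.18 log units; within the scatter) is expected to be small, at or only just beyond the usual scatter, leaning toward weaker inhibition. Compound 4 is therefore expected to give about 9000 nM in this assay, with a plausible range from 3000 nM to 30000 nM.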

Compound 4, half-maximal inhibitory concentration: 10000 nM
Estimate against measurement, compound 4: 1.1-fold (0.05 log units) below, within the range that was stated.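

In this assay, replacing the 4-fluorophenyl with 2-chlorophenyl on a saturated chain carbon bound to an aromatic nitrogen gives a 1.7-fold higher number from compound 1 to compound 4 (0.22 log units; within the scatter), so this change cannot be told apart from repeat-measurement noise. Going by these compounds alone, this is the first single-place comparison, and it shows that this position accepts a different halogen on the phenyl ring, at a different place on that ring, with no readable effect on the number. Compound 1 and compound 4 both give measured numbers rather than limits, which sets them apart from the values that reach the limit of the assay: the limit of > 100000 nM in this assay, at which 2 of the 4 values shown sit.

Within the data shown here, the single pair changes the halogen and its place on the ring together, so it cannot say what either would do alone, and it gives no measured property that could account for the result. The compounds shown also leave open whether this position would accept an amine or a carboxylic acid in place of the phenyl ring, or a longer chain between the ring and the aromatic nitrogen.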